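Nitrophenyl to Cyanophenyl on Two Related Sulfonyl Cores

The source may hold more compounds than are shown below. What is called first, only, known or untested is meant among the compounds shown, and "the series" means these compounds.

Compound 1 `COc1cc(/C=C2\CN(S(=O)(=O)c3ccc(F)cc3)C/C(=C\c3cccc([N+](=O)[O-])c3)C2=O)cc(OC)c1OC`: 3270 nM
Compound 2 `COc1cc(/C=C2\CN(S(=O)(=O)c3ccc(F)cc3)C/C(=C\c3ccc(C#N)cc3)C2=O)cc(OC)c1OC`: 4980 nM
Compound 3 `COc1cc(/C=C2\CN(S(=O)(=O)c3ccc(NC(C)=O)cc3)C/C(=C\c3cccc([N+](=O)[O-])c3)C2=O)cc(OC)c1OC`: 2550 nM

All three were tested in a functional assay on QGY-7703 cells (Homo sapiens) for cytotoxicity, read by MTT assay, with a stated time of 24 h; a higher number here means a weaker inhibitor, a lower number a stronger inhibitor. Compounds 1 and 2 share one core and differ by a single change: 4-cyanophenyl in place of 3-nitrophenyl on a double-bonded chain carbon bound to a double-bonded ring carbon. That change made a step of a 1.5-fold higher number from compound 1 to compound 2 (0.18 log units; within the scatter), a small shift that repeated runs of this assay could produce on their own.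

Compound 3 shares its core with compound 1 but differs from it by acetamido in place of fluoro on an aromatic carbon, and the two are separated by a step of a 1.3-fold lower number from compound 1 to compound 3 (0.11 log units; within the scatter), again within the usual scatter.

Compound 4 `COc1cc(/C=C2\CN(S(=O)(=O)c3ccc(NC(C)=O)cc3)C/C(=C\c3ccc(C#N)cc3)C2=O)cc(OC)c1OC` has not yet been measured in this assay. It stands to compound 3 as compound 2 stands to compound 1, through (4-cyanophenyl in place of 3-nitrophenyl on a double-bonded chain carbon bound to a double-bonded ring carbon); the place of the change is described in the same words in both pairs, so it is the same change on a different core.

Among the measured compounds shown here, only one measured example of this change exists, so the expectation rests on it alone: from compound 3 to compound 4 a step of about a 1.5-fold higher number from compound 3 to compound 4 (0.17 log units; within the scatter) is expected, mirroring a 1.5-fold higher number from compound 1 to compound 2 (0.18 log units; within the scatter). Compound 4 is therefore estimated at 3800 nM, within a range from 1900 nM to 7600 nM.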

Compound 4, half-maximal inhibitory concentration: 1890 nM
The estimate for compound 4 lay 2.0-fold (0.30 log units) above the measured number, and the stated range ends above it.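

In this assay, putting 4-cyanophenyl in place of 3-nitrophenyl on the acetamido core gives a 1.3-fold lower number from compound 3 to compound 4 (0.13 log units; within the scatter), so on both cores this change stays inside the ordinary variation of repeated measurements, and the two results cannot be told apart: the same change on two cores in this assay, a 1.5-fold higher number (0.18 log units; within the scatter) from compound 1 to compound 2 and a 1.3-fold lower number (0.13 log units; within the scatter) from compound 3 to compound 4, 2.1-fold (0.31 log units) apart, within the scatter of two such steps. Among the compounds shown here, putting acetamido in place of fluoro on the 4-cyanophenyl core gives a 2.6-fold lower number from compound 2 to compound 4 (0.42 log units; beyond the scatter), the only step in this set beyond the scatter, yet it also cannot be separated from the same change on the other core: the same change on two cores in this assay, a 1.3-fold lower number (0.11 log units; within the scatter) from compound 1 to compound 3 and a 2.6-fold lower number (0.42 log units; beyond the scatter) from compound 2 to compound 4, 2.1-fold (0.31 log units) apart, within the scatter of two such steps. Both changes therefore carried across these two cores with no detectable difference, but each rests on a single pair of steps, which does not show that the steps are truly equal or that either change would behave the same way on a further core.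

The compounds shown leave open how other groups would behave on that aromatic carbon, such as an amine or a carboxylic acid in place of acetamido. They also leave open whether the step to compound 4 would hold in other cell lines.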